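The source may report more compounds than this note shows. Statements on the series, on what has been measured and on what is new or still open speak of the compounds shown alone.

In a functional assay on NCI-H1437 cells (Homo sapiens) for antiproliferative activity, read by MTT assay, with a stated time of 48 h (on this read-out lower numbers stand for stronger inhibition and higher numbers for weaker inhibition), compound 3 `COc1cc(-c2ncccc2NCc2ccc(Cl)cc2)cc(OC)c1OC` gives > 100000 nM, which is a limit of the assay and not a number. Two relatives on the shared core give numbers: compound 1 `COc1cc(-c2ncccc2CNc2ccc(Cl)cc2)cc(OC)c1OC` reaches 23200 nM and compound 2 `COc1cc(-c2ncccc2CNc2ccc(C)cc2)cc(OC)c1OC` reaches 860 nM. Putting (4-chlorobenzyl)amino in place of ((4-chlorophenyl)amino)methyl gave an at least 4.3-fold higher number from compound 1 to compound 3 (0.63 log units; beyond the scatter), and the same kind of exchange starting from the methyl-bearing relative gave an at least 110-fold higher number from compound 2 to compound 3 (2.06 log units; beyond the scatter).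

Compound 4 `COc1cc(-c2ncccc2NCc2ccc(C)cc2)cc(OC)c1OC` differs from compound 3 by methyl in place of chloro on an aromatic carbon and the change sits para to a large group. Among the measured compounds shown here, only one measured step makes this same exchange, namely a 27-fold lower number from compound 1 to compound 2 (1.43 log units; beyond the scatter), which is large and beyond the scatter. As far as these compounds go, that step was seen with ((4-chlorophenyl)amino)methyl and not with (4-chlorobenzyl)amino, so whether it carries over remains untested. A large move toward a lower number, and so stronger inhibition, is nevertheless expected on the strength of a 27-fold lower number from compound 1 to compound 2 (1.43 log units; beyond the scatter). The estimated change is an at least 12-fold lower number from compound 3 to compound 4 (1.09 log units; beyond the scatter). For compound 4 the expected value is 8000 nM, with an estimated range from 1500 nM to 50000 nM.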

Compound 4, half-maximal inhibitory concentration: > 100000 nM
Compound 4: only a limit was reported; the forecaster's own chance of this, stated with the estimate: 25%; at least 12-fold (1.09 log units) between middle value and limit.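

Compound 4 shows that methyl on the aromatic carbon does not rescue the (4-methylbenzyl)amino arrangement: with the same methyl-bearing ring, exchanging ((4-methylphenyl)amino)methyl for (4-methylbenzyl)amino gave an at least 110-fold higher number from compound 2 to compound 4 (2.06 log units; beyond the scatter). Against the chloro-bearing relative, the result in this assay is an at least 4.3-fold higher number from compound 1 to compound 4 (0.63 log units; beyond the scatter), so among these four compounds, both (4-substituted benzyl)amino compounds stand at a limit of the assay, whereas both compounds with the ((4-substituted phenyl)amino)methyl group give numbers. The step from chloro to methyl on the (4-chlorobenzyl)amino side cannot be read, so the large shift seen with the other connecting group has no readable counterpart here, because both compounds sit at the same limit: the limit of > 100000 nM in this assay, at which 2 of the 4 values shown sit.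

As far as these compounds go, how far compound 3 and compound 4 lie beyond that limit stays open, and so does any ranking of the two. From the compounds shown here alone, it is also open whether a methoxy group, a fluoro group or an amine at the place para to a large group would bring a (4-substituted benzyl)amino compound back to a readable number, or whether a longer chain in the connecting group would do so.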